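The source may hold more compounds than are shown below. What is called first, only, known or untested is meant among the compounds shown, and "the series" means these compounds.

Compound 1 `Cc1c(C)c2c(c(C)c1N)CC(C)(C)O2` is the reference here. In a functional assay on the whole organism with Mus musculus as the target (a higher number here means that more compound is needed for the effect, a lower number that less compound is needed), compound 1 gives 7.8 mg/kg, the lowest of the two numbers measured. Compound 2 `Cc1cc(N)c(C)c2c1OC(C)(C)C2` gives 32.3 mg/kg, and the change is a 4.1-fold higher number from compound 1 to compound 2 (0.62 log units; beyond the scatter). Compound 3 `Cc1c(N)c(C)c2c(c1CN1CCCCC1)OC(C)(C)C2` reaches only a limit of the assay, > 50 mg/kg, so its exact dose is not known. That step is an at least 6.4-fold higher number from compound 1 to compound 3 (0.80 log units; beyond the scatter), because the value sits at the limit of > 50 mg/kg in this assay, at which 1 of the 3 values shown sits.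

Compound 4 `Cc1c(C)c2c(c(C)c1N)CC(C)(CCN1CCCCC1)O2` differs from compound 1 by (piperidin-1-yl)methyl in place of hydrogen on a saturated chain carbon bound to a saturated ring carbon. Among the compounds with values here, the nearest precedent is the piperidine addition in compound 3, which was an at least 6.4-fold higher number from compound 1 to compound 3 (0.80 log units; beyond the scatter), although the group enters at a different place. A larger dose is therefore expected for compound 4. Compound 4 is expected at 30 mg/kg, within 10 mg/kg to 80 mg/kg. The expected step is a 3.8-fold higher number from compound 1 to compound 4 (0.59 log units; beyond the scatter).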

Compound 4, dose for 50% inhibition: 18.4 mg/kg
Estimate against measurement, compound 4: 1.6-fold (0.21 log units) above; the range from low to high includes it.
By their numbers in this assay, from the lowest: compound 1; then compounds 4 and 2 (each within the scatter of the next). At a limit, above all of these: compound 3.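

At this place, on a saturated chain carbon bound to a saturated ring carbon, the added (piperidin-1-yl)methyl raises the dose needed, yet still gives a readable number: a 2.4-fold higher number from compound 1 to compound 4 (0.37 log units; beyond the scatter). Compound 3, with its piperidin-1-yl on a saturated chain carbon bound to an aromatic carbon, stays at a limit, > 50 mg/kg. A piperidine ring therefore does not always push a compound to that limit in this assay.

No measurement shown explains the rise in dose. On these data alone, whether a morpholine ring or a simple dimethylamino group at this place would bring the dose closer to that of compound 1 remains open.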